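The compounds below may be only part of what the source reports. "The series", "measured", "known", "first", "only" and "open" are said of these compounds alone.

Compound 1 `COc1ccc(-c2cc(=O)c3c(OC)cc(OC)cc3n2C)cc1` is the only one of the three measured compounds to give a number in an ADME assay on BJ cells (Homo sapiens) for antiproliferative activity, with a stated time of 72 h (a higher number here means that more compound is needed for the effect, a lower number that less compound is needed), where compound 1 gives 68000 nM. Compound 2 `COc1ccc(-c2cc(=O)c3c(OC)cc(OC)cc3n2Cc2ccccc2)cc1` gives only a limit of > 34400 nM in this assay. Compound 3 `COc1ccc(-c2cc(=O)c3c(OC)cc(OC)cc3n2S(=O)(=O)c2cc(Cl)cc(Cl)c2O)cc1` likewise gives only a limit of > 37900 nM in this assay. The step that the limit leaves unreadable from compound 1 to compound 2 therefore cannot be read. Compound 4 `COc1ccc(-c2cc(=O)c3c(OC)cc(OC)cc3n2S(=O)(=O)c2cccc(Br)c2)cc1` carries (3-bromophenyl)sulfonyl in place of methyl on an aromatic nitrogen. Within the data shown here, compound 3 offers only its limit, so no measured step gives a readable size for this kind of change, and nothing here points to a move beyond the scatter. The expected step is a 1.1-fold lower number from compound 1 to compound 4 (0.05 log units; within the scatter), with a good chance that this assay again reports only a limit. The estimate for compound 4 is 60000 nM, between 25000 nM and 150000 nM.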

Compound 4, half-maximal effective concentration: > 58600 nM
Compound 4: a limit, no number; the forecaster's own chance of this, stated with the estimate: 65%; the middle value is on the limit's open side.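

Among these compounds, compound 4 gives only a limit, so no step between it and compound 1, compound 2 or compound 3 can be read. The compounds shown leave open how far any group on the aromatic nitrogen moves the number in this assay.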